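Methoxy for methyl on the anilino arm of the series

The compounds below may be only part of what the source reports. "The series", "measured", "known", "first", "only" and "open" are said of these compounds alone.

Compound 1 `COc1cc(C(=O)c2sc3ccccc3c2-c2ccc(C)cc2)cc(OC)c1OC`, compound 2 `COc1ccc(-c2c(C(=O)c3cc(OC)c(OC)c(OC)c3)sc3ccccc23)cc1` and compound 3 `COc1cc(C(=O)c2sc3ccccc3c2Nc2ccc(C)cc2)cc(OC)c1OC` share a core that carries a trimethoxybenzoyl group; compound 4 `COc1ccc(Nc2c(C(=O)c3cc(OC)c(OC)c(OC)c3)sc3ccccc23)cc1` is not yet measured. In a functional assay on Jurkat cells (Homo sapiens) for antiproliferative activity, read by MTT assay, with a stated time of 72 h (a higher number here means a weaker inhibitor, a lower number a stronger inhibitor), compound 1 gives 3300 nM, compound 2 gives 1600 nM and compound 3 gives 1700 nM.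

The change under study is methoxy in place of methyl on an aromatic carbon. Between the two measured compounds it made a step of a 2.1-fold lower number from compound 1 to compound 2 (0.31 log units; beyond the scatter). The core of compound 3 differs from that of compound 1 by (4-methylphenyl)amino in place of 4-methylphenyl on an aromatic carbon; this change gave a 1.9-fold lower number from compound 1 to compound 3 (0.29 log units; within the scatter), and compound 2 and compound 3 are related by a 1.1-fold higher number from compound 2 to compound 3 (0.03 log units; within the scatter).

Compound 4 differs from compound 3 by methoxy in place of methyl on an aromatic carbon. The place description reads the same as for the step from compound 1 to compound 2, so this is the same change made on the anilino core. Within the data shown here, only one measured example of it exists here, so the expectation rests on that single step, a 2.1-fold lower number from compound 1 to compound 2 (0.31 log units; beyond the scatter), and on the closeness of compound 2 and compound 3 in this assay, which hints that the two cores behave alike. The step from compound 3 to compound 4 is expected to be a 1.7-fold lower number from compound 3 to compound 4 (0.23 log units; within the scatter), somewhat smaller than the measured one to allow for the scatter. Compound 4 is therefore estimated at 1000 nM, with a likely range from 500 nM to 2000 nM.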

Compound 4, half-maximal inhibitory concentration: 3500 nM
Compound 4: middle estimate off by 3.5-fold (0.54 log units), on the low side; measured number outside the range, above it.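

In this assay, methoxy in place of methyl on an aromatic carbon does not carry from one core to the other, and its direction reverses: the same change on two cores in this assay, a 2.1-fold lower number (0.31 log units; beyond the scatter) from compound 1 to compound 2 and a 2.1-fold higher number (0.31 log units; beyond the scatter) from compound 3 to compound 4, 4.2-fold (0.63 log units) apart, beyond the scatter of two such steps

The new step on the core of compound 3 is a 2.1-fold higher number from compound 3 to compound 4 (0.31 log units; beyond the scatter), and the core change with methoxy present gives a 2.2-fold higher number from compound 2 to compound 4 (0.34 log units; beyond the scatter), whereas with methyl present it gave a 1.9-fold lower number from compound 1 to compound 3 (0.29 log units; within the scatter), which lies within the scatter, so the effect of each change here depends on the other. The pair that differs in both changes shows a 1.1-fold higher number from compound 1 to compound 4 (0.03 log units; within the scatter), also within the scatter, so the two changes together leave no readable difference. Among these compounds, these four compounds show only that a step measured on one core was a poor guide on the other in this one cell assay; they do not show why the direction reverses, and with one pair per core they do not show whether the same holds for any other group.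

Going by these compounds, it remains open whether ethyl, chloro or hydroxyl at the same place would follow the methyl or the methoxy compounds on each core. On these data alone, it also remains open whether an ether oxygen or a methylene link in place of the amine nitrogen would behave like either core.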